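Fluoro in place of acetyl on the shared urea core

The source may report more compounds than this note shows. Statements on the series, on what has been measured and on what is new or still open speak of the compounds shown alone.

Of the compounds shown here, three built on one core have been tested in an ADME assay on the whole organism with Oryza sativa as the target, tested at 1 uM; a lower number here means a stronger effect, a higher number a weaker effect of the compound at the concentration tested. Compound 1 `CCCCCCCc1ccc(NC(=O)N[C@H](C)c2ccccc2)cc1` gives 100%. Compound 2 `C[C@@H](NC(=O)Nc1ccc(C(F)(F)F)cc1)c1ccccc1` gives 89%, and compound 3 `CC(=O)c1ccc(NC(=O)N[C@H](C)c2ccccc2)cc1` gives 93%. Among the compounds with values here, compound 3 therefore stands second highest of the three numbers: the step of a number 4 percentage points higher from compound 2 to compound 3 (within the scatter) lies within the scatter, as does the step of a number 7 percentage points lower from compound 1 to compound 3 (within the scatter), so none of these values can be ordered against the others; only the step of a number 11 percentage points lower from compound 1 to compound 2 (beyond the scatter) reaches beyond the scatter, and it is modest.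

Compound 4 `C[C@@H](NC(=O)Nc1ccc(F)cc1)c1ccccc1` is the next step from compound 3: fluoro in place of acetyl on an aromatic carbon. The two measured steps that touch the acetyl group, a number 7 percentage points lower from compound 1 to compound 3 (within the scatter) and a number 4 percentage points higher from compound 2 to compound 3 (within the scatter), were both within the scatter, so a small group entering at the same place is expected to move the number little. The expected step is a number 1 percentage points lower from compound 3 to compound 4 (within the scatter), no change beyond the scatter. Compound 4 is estimated at 92%, between 80% and 100%.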

Compound 4, a percentage reported as activity, at one concentration (the size of the read-out at that concentration, not a potency): 96%
Compound 4: middle estimate off by 4 percentage points, on the low side; the measured number falls inside the stated range.
By their numbers in this assay, from the lowest: compounds 2, 3, 4 and 1 (each within the scatter of the next, the first and the last beyond it).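

In this assay, fluoro, a single heavy atom, replaces acetyl with a number 3 percentage points higher from compound 3 to compound 4 (within the scatter), replaces trifluoromethyl with a number 7 percentage points higher from compound 2 to compound 4 (within the scatter), and replaces heptyl with a number 4 percentage points lower from compound 1 to compound 4 (within the scatter). This aromatic carbon therefore carries the smallest group of the series with no step beyond the scatter to any of the other three, so compound 4 cannot be ordered against any of them, even though a number 11 percentage points lower from compound 1 to compound 2 (beyond the scatter) separates compound 1 and compound 2. Nothing shown here gives a reason for these numbers.

The compounds leave open whether an amine or a carboxylic acid on this aromatic carbon would give a step beyond the scatter from fluoro. They also leave open what a change elsewhere on the shared core would do.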